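Chalcone-type Series: Aryl Ketone Substituent Step

The source may hold more compounds than are shown below. What is called first, only, known or untested is meant among the compounds shown, and "the series" means these compounds.

Measured so far:
compound 1 `O=C(/C=C/c1ccncc1)c1ccc(Cl)cc1` — 60000 nM
compound 2 `O=C(/C=C/c1ccncc1)c1ccco1` — 50000 nM

In a functional assay with Rattus norvegicus as the target (on this read-out lower numbers stand for stronger inhibition and higher numbers for weaker inhibition), compound 1 gives 60000 nM, the higher of the two numbers; compound 2 gives 50000 nM, and the gap between the two lies within the scatter, so no order between them is claimed.

Compound 3 `CSc1ccc(C(=O)/C=C/c2ccncc2)cc1` is not yet measured. It differs from compound 1 by methylsulfanyl in place of chloro on an aromatic carbon. For the measured compounds named here, no step between measured compounds covers a change of this kind, so nothing here tells its size. The step from compound 1 to compound 3 in this assay is expected to stay within the scatter, a 1.2-fold lower number from compound 1 to compound 3 (0.08 log units; within the scatter).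

For compound 3 the number expected in this assay is 50000 nM, with a range from 15000 nM to 160000 nM.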

Compound 3, half-maximal inhibitory concentration: 33000 nM
Compound 3: middle estimate off by 1.5-fold (0.18 log units), on the high side; low and high end bracket the measured number.
By their numbers in this assay, from the lowest: compounds 3, 2 and 1 (each within the scatter of the next).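

In this assay the exchange of chloro for methylsulfanyl on the aromatic carbon para to a large group gives a 1.8-fold lower number from compound 1 to compound 3 (0.26 log units; within the scatter) and so shows no change that can be told from the scatter. At this position, a group carrying a sulfur and a hydrogen-bond acceptor is thus tolerated without a clear loss or gain. No measurement at hand bears on the reason for this result. Open, on these data alone, is whether an amine, a carboxylic acid or a longer chain such as ethylsulfanyl on this carbon would move the number beyond the scatter. Changes elsewhere on the shared core also remain open.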